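The source may report more compounds than this note shows. Statements on the series, on what has been measured and on what is new or still open speak of the compounds shown alone.

Compound 3 `CC(C)SC(=O)N1CCC(Oc2ncnc3c2CCN3c2ccc(S(C)(=O)=O)cc2F)CC1` gives the lowest number of the three measured compounds in a functional assay on CHO-K1 cells for agonist activity at Glucose-dependent insulinotropic receptor (Homo sapiens), read by a luciferase reporter, with a stated time of 5 h (a lower number here means that less compound is needed, a higher number that more compound is needed for the effect), at 10 nM; compound 2 `CCSC(=O)N1CCC(Oc2ncnc3c2CCN3c2ccc(S(C)(=O)=O)cc2F)CC1` gives 31.6 nM and compound 1 `CCOC(=O)N1CCC(Oc2ncnc3c2CCN3c2ccc(S(C)(=O)=O)cc2F)CC1` gives 251 nM. Compound 4 `CS(=O)(=O)c1ccc(N2CCc3c(OC4CCN(C5=NCCCN5)CC4)ncnc32)c(F)c1` differs from compound 3 in that (a group of 6 heavy atoms (4 carbon, 2 nitrogen; one six-membered non-aromatic ring with 2 hetero atoms) in place of a group of 6 heavy atoms (4 carbon, 1 oxygen, 1 sulfur; no ring), on an amine nitrogen in a ring). The measured steps of a 7.9-fold lower number from compound 1 to compound 2 (0.90 log units; beyond the scatter), a 25-fold lower number from compound 1 to compound 3 (1.40 log units; beyond the scatter) and a 3.2-fold lower number from compound 2 to compound 3 (0.50 log units; beyond the scatter) each alter only the chain attached to the carbonyl carbon, so none of them covers a change that removes the carbonyl altogether. The direction of the step is therefore uncertain, and a modest move toward a higher number with a wide range is the expectation. Compound 4 is expected to give 100 nM in this assay, between 10 nM and 1000 nM, an expected step of a 10-fold higher number from compound 3 to compound 4 (1.00 log units; beyond the scatter).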

Compound 4, half-maximal effective concentration: 2000 nM
Compound 4: the middle estimate sits 20-fold (1.30 log units) below what was measured; the whole stated range lies below it.
By their numbers in this assay, from the lowest: compound 3; then compound 2; then compound 1; then compound 4.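

In this assay, the amine nitrogen in a ring responds strongly to this swap: the six-membered non-aromatic ring with 2 hetero atoms in place of (isopropylsulfanyl)carbonyl gives a 200-fold higher number from compound 3 to compound 4 (2.30 log units; beyond the scatter). The same ring also gives a 63-fold higher number from compound 2 to compound 4 (1.80 log units; beyond the scatter) and an 8.0-fold higher number from compound 1 to compound 4 (0.90 log units; beyond the scatter), so all three carbonyl-bearing groups shown here need less compound than this ring does. Nothing available explains the loss. The compounds shown leave open whether losing the carbonyl or adding the ring drives this step. A plain isopropyl group, or a carbonyl bearing an amine, on that nitrogen would help separate the two.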